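Arylthio enone series: swapping the thienyl for methoxyphenyl

A few compounds are considered here, and "the series" means these few. Any claim that something is new, unique, unknown or untested is made for them only; others in the source may bear on it.

Three analogues of the same arylthio enone scaffold have been run in a functional assay on DU-145 cells (Homo sapiens) for inhibition, read by trypan blue exclusion, with a stated time of 96 h; a higher number here means a weaker inhibitor of growth, a lower number a stronger inhibitor of growth. Compound 1 `Cc1ccc(CS/C(=C/c2sccc2C)C(=O)c2ccc(Cl)cc2)cc1` gives 10000 nM. Compound 2 `COc1ccccc1/C=C(/SCc1ccc(C)cc1)C(=O)c1ccc(Cl)cc1` gives 10000 nM. For the measured compounds named here, compound 3 `Cc1ccsc1/C=C(/SCc1ccc(Cl)cc1)C(=O)c1ccc(Br)cc1` gives 25000 nM, the highest number of the three, and since both gaps to compound 1 and compound 2 lie beyond the usual scatter, compound 3 is the weakest growth inhibitor in this assay so far.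

Going by the values given here, the one pairwise change that is counted here is 2-methoxyphenyl in place of 3-methylthiophen-2-yl on a double-bonded chain carbon bound to a double-bonded chain carbon. Its effect is given by no change at the digits printed from compound 1 to compound 2 (within the scatter). Compound 3 carries a different core from compound 1; how the two cores differ is not broken down here, so the two values are only compared as they stand.

The unmeasured compound 4 `COc1ccccc1/C=C(/SCc1ccc(Cl)cc1)C(=O)c1ccc(Br)cc1` is obtained from compound 3 by 2-methoxyphenyl in place of 3-methylthiophen-2-yl on a double-bonded chain carbon bound to a double-bonded chain carbon. Among the compounds with values here, this is the same change as the one from compound 1 to compound 2, made at the same place, and it occurs twice among the four compounds. Because no change at the digits printed from compound 1 to compound 2 (within the scatter) shows no movement beyond the scatter, the expectation for compound 4 is likewise a flat step, no change at the digits printed from compound 3 to compound 4 (within the scatter), with the caveat that a single precedent on a different core is thin support. Compound 4 is therefore estimated at 25000 nM in this assay, with a plausible range of 10000 nM to 60000 nM.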

Compound 4, concentration for 50% growth inhibition: 1000 nM
Beside the measured number, compound 4's estimate is 25-fold (1.40 log units) above it; the whole stated range lies above it.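

In this assay, 2-methoxyphenyl in place of 3-methylthiophen-2-yl gives a 25-fold lower number from compound 3 to compound 4 (1.40 log units; beyond the scatter), so this change does not carry a single size of effect from one core to the other: the same change on two cores in this assay, no change at the digits printed (within the scatter) from compound 1 to compound 2 and a 25-fold lower number (1.40 log units; beyond the scatter) from compound 3 to compound 4, 25-fold (1.40 log units) apart, beyond the scatter of two such steps

The flat step on the core of compound 1 is therefore a poor guide to the step on the core of compound 3, and in this series the effect of the swap has to be read core by core. The two cores differ in more than one place, so these two pairs show that the outcome of the change depends on its surroundings, but they do not show which difference between the cores goes with the gap, or why it arises, and they give no rule for any further core.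

From the compounds shown here alone, it remains open whether the large step appears on a core that keeps only one of the features separating the core of compound 1 from the core of compound 3. Also open, going by these compounds, is whether other groups on the same carbon, such as an unsubstituted phenyl, an amine or a carboxylic acid, would behave like 2-methoxyphenyl on the core of compound 3.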